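The compounds below may be only part of what the source reports. "The series", "measured", "known", "first", "only" and "open" are said of these compounds alone.

Measured so far in a functional assay on a cell-free system (plasma, Homo sapiens), with a stated time of 3 min; on this read-out lower numbers stand for stronger inhibition and higher numbers for weaker inhibition

- compound 1 `O=C(NCc1cc(Cl)ccc1-n1cnnn1)[C@@H]1CC=NN1C(=O)[C@H](O)c1ccccc1` gives 840 nM
- compound 2 `CC(C)(C)[C@@H](O)C(=O)N1C[C@@H]2C[C@@H]2[C@H]1C(=O)NCc1cc(Cl)ccc1-n1cnnn1` gives 570 nM
- compound 3 `CC(C)(C)[C@@H](O)C(=O)N1C[C@H]2C[C@H]2[C@H]1C(=O)NCc1cc(Cl)ccc1-n1cnnn1` gives 1200 nM

Compound 2 and compound 1 sit together at the low end of this short series, within the scatter of each other, and only compound 3 stands apart from compound 2. The next compound, compound 4 `O=C(NCc1cc(Cl)ccc1-n1cnnn1)[C@@H]1[C@H]2C[C@H]2CN1C(=O)[C@H](O)Cn1cccn1`, has not been measured. It differs from compound 2 as follows: (1H-pyrazol-1-yl)methyl in place of tert-butyl on a saturated chain carbon bound to a carbonyl carbon and an oxygen on a saturated carbon. In words, this is (1H-pyrazol-1-yl)methyl in place of tert-butyl on a saturated chain carbon bound to a carbonyl carbon and an oxygen on a saturated carbon.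

Among the measured compounds shown here, only one measured step offers any guide, and only loosely: a 2.1-fold higher number from compound 2 to compound 3 (0.32 log units; beyond the scatter). That modest step comes with the fact that compounds 2 and 3 differ only in the configuration as drawn, so it does not test this swap of groups. Still, compound 1 (840 nM) and compound 3 (1200 nM) both stay close to compound 2, so no large change is expected. The expected step is small and slightly upward in this assay, estimated as a 1.6-fold higher number from compound 2 to compound 4 (0.20 log units; within the scatter). For compound 4 the expected value is 900 nM, with an estimated range from 280 nM to 2900 nM.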

Compound 4, half-maximal inhibitory concentration: 1800 nM
Estimate against measurement, compound 4: 2.0-fold (0.30 log units) below; low and high end bracket the measured number.
By their numbers in this assay, from the lowest: compounds 2, 1, 3 and 4 (each within the scatter of the next, the first and the last beyond it).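

In this assay, the swap gives a 3.2-fold higher number from compound 2 to compound 4 (0.50 log units; beyond the scatter). Among the compounds shown here, this is the first reading of how the saturated chain carbon bound to a carbonyl carbon and an oxygen on a saturated carbon responds to a change of group: on this core, the number goes up beyond the usual scatter when (1H-pyrazol-1-yl)methyl takes the place of tert-butyl. The earlier step could not show this, since no group changed in it: the fact that compounds 2 and 3 differ only in the configuration as drawn

Nothing shown here explains why the number rises with this swap. For the compounds shown here, the single step also changes several things together, as the entering group adds a five-membered aromatic ring, two nitrogen atoms and two hydrogen-bond acceptors, so the effect of each cannot be separated. An isopropyl group or a benzyl group at this same place on this core would add further steps, and these could help show whether the rise goes with the loss of tert-butyl or with the arrival of the pyrazole ring.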